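Removing the methoxy from compound 3

A few compounds are considered here, and "the series" means these few. Any claim that something is new, unique, unknown or untested is made for them only; others in the source may bear on it.

Values in a functional assay (aorta) with Oryctolagus cuniculus as the target (on this read-out lower numbers stand for tighter binding and higher numbers for weaker binding), for the measured compounds:
- compound 1 `COC(=O)c1ccc(OCCCN2CCC(C(c3ccc(F)cc3)c3ccc(F)cc3)CC2)c(OC)c1` gives 1.26 nM
- compound 2 `COc1cc(OCCCN2CCC(C(c3ccc(F)cc3)c3ccc(F)cc3)CC2)ccc1C(C)=O` gives 3.16 nM
- compound 3 `COc1ccc(OCCCN2CCC(C(c3ccc(F)cc3)c3ccc(F)cc3)CC2)cc1` gives 2.51 nM

Compound 3 stands within the scatter of both other compounds. Compound 4 `Fc1ccc(C(c2ccc(F)cc2)C2CCN(CCCOc3ccccc3)CC2)cc1` differs from it by hydrogen in place of methoxy on an aromatic carbon with hydrogen in place of methoxy, para to a large group. Within the data shown here, no measured step removes this group alone. The nearest evidence is a 2.0-fold higher number from compound 1 to compound 3 (0.30 log units; within the scatter) and a 1.3-fold lower number from compound 2 to compound 3 (0.10 log units; within the scatter) as changes on the same oxygen, and the largest step is a 2.5-fold higher number from compound 1 to compound 2 (0.40 log units; beyond the scatter) in the same series. No step beyond the scatter is therefore expected in this assay for this change. The expected step is a 1.2-fold higher number from compound 3 to compound 4 (0.08 log units; within the scatter) in size. Compound 4 is estimated at 3 nM (range 1.2 nM to 7.5 nM) in this read-out.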

Compound 4, dissociation constant: 1.59 nM
The estimate for compound 4 lay 1.9-fold (0.28 log units) above the measured number; low and high end bracket the measured number.
By their numbers in this assay, from the lowest: compounds 1, 4, 3 and 2 (each within the scatter of the next, the first and the last beyond it).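

In this assay, hydrogen replacing methoxy on the aromatic carbon para to a large group gives a 1.6-fold lower number from compound 3 to compound 4 (0.20 log units; within the scatter), so the methoxy is not required at this place. Plain phenyl on the oxygen also stays close to both more substituted compounds, with a 2.0-fold lower number from compound 2 to compound 4 (0.30 log units; within the scatter) and a 1.3-fold higher number from compound 1 to compound 4 (0.10 log units; within the scatter), although those two compounds lie beyond the scatter of each other. Nothing measured here accounts for these numbers.

From the compounds shown here alone, whether an amine or a carboxylic acid at this place would hold the number within the scatter remains open.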